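The source may hold more compounds than are shown below. What is called first, only, known or untested is meant among the compounds shown, and "the series" means these compounds.

Values in a functional assay on K562 cells (Homo sapiens) for antiproliferative activity, read by MTT assay, with a stated time of 72 h; a higher number here means a weaker inhibitor, a lower number a stronger inhibitor:
- compound 1 `O=C1C[C@@H]2O[C@H]3[C@H](c4ccccc4)c4ccccc4CO[C@H]3[C@@H]2O1`: 1210 nM
- compound 2 `O=C1C[C@H]2O[C@H](Cc3ccccc3)[C@H](O)[C@H]2O1`: 510 nM
- compound 3 `Cc1ccccc1[C@H](c1ccccc1)[C@H]1O[C@@H]2CC(=O)O[C@@H]2[C@H]1O`: 1560 nM
- compound 4 `O=C1C[C@H]2O[C@@H]3[C@@H](c4ccccc4)c4ccccc4CO[C@@H]3[C@H]2O1`: not yet measured

Compound 1, at 1210 nM, lies within the scatter of compound 3, at 1560 nM. Compound 2 has the lowest number, and its gap to compound 1 is beyond the scatter.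

The next change is purely one of configuration: the two compounds have the same atoms and bonds and differ only in configuration as drawn: 5 of 5 stereo elements differ (all stereocentres are inverted: mirror images); a stereocentre at a saturated ring carbon is drawn S in compound 1 and R in compound 4; a stereocentre at a saturated ring carbon is drawn S in compound 1 and R in compound 4; a stereocentre at a saturated ring carbon is drawn R in compound 1 and S in compound 4; a stereocentre at a saturated ring carbon is drawn R in compound 1 and S in compound 4. Going by the values given here, no mirror-image pair has been measured. Among the compounds with values here, the only measured step, a 3.1-fold higher number from compound 2 to compound 3 (0.49 log units; beyond the scatter), comes from adding a 2-methylphenyl group and involves no inversion. It therefore gives only a rough idea of how far values can move here and gives no direction for compound 4. In this assay, a shift of similar size is expected to be possible either way, so the central estimate stays close to compound 1.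

For compound 4 the estimated value is 1000 nM, with an expected range of 250 nM to 4500 nM. The expected central outcome is a 1.2-fold lower number from compound 1 to compound 4 (0.08 log units; within the scatter).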

Compound 4, half-maximal inhibitory concentration: 1430 nM
Estimate against measurement, compound 4: 1.4-fold (0.16 log units) below; low and high end bracket the measured number.
By their numbers in this assay, from the lowest: compound 2; then compounds 1, 4 and 3 (each within the scatter of the next).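

In this assay, going by these compounds alone, the inversion of every stereocentre gives a 1.2-fold higher number from compound 1 to compound 4 (0.07 log units; within the scatter) and this is the first mirror-image pair. The two mirror-image forms of the shared core are therefore not told apart by this read-out, a result that holds for this pair only and says nothing yet about single stereocentres. The comparison carries no other structural change: the fact that compounds 1 and 4 differ only in the configuration as drawn

Open, on these data alone, is whether compound 2 or compound 3 would behave alike on full inversion, and whether inverting only some of the stereocentres of compound 1 would leave its number in place. Also open, as far as these compounds go, is whether an amine or a carboxylic acid on a phenyl group of compound 1 would keep the two mirror images this close.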